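This account rests on a few compounds, and the source may have more. Where it says the series, first, only, none or still open, it means among the compounds named here.

Measured compounds:
- compound 1 `CNc1nc(N)c2nc(O)n(Cc3ccccc3)c2n1` — 1 uM
- compound 2 `Cc1nc(N)c2nc(O)n(Cc3ccccc3)c2n1` — 1 uM
- compound 3 `CCNc1nc(N)c2nc(O)n(Cc3ccccc3)c2n1` — 1 uM

All three share one core and differ only in the group on one aromatic carbon. In a functional assay (spleen, spleen) for activation, with Mus musculus as the target (a higher number here means that more compound is needed for the effect, a lower number that less compound is needed), compound 1 gives 1 uM. Compound 2 gives 1 uM, and compound 3 gives 1 uM. The three steps linking them are flat: no change at the digits printed from compound 1 to compound 2 (within the scatter), no change at the digits printed from compound 1 to compound 3 (within the scatter) and no change at the digits printed from compound 2 to compound 3 (within the scatter). Compound 3 therefore stands level with compounds 1 and 2; nothing in the set so far separates the three substituents at this position.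

Compound 4 `CCCc1nc(N)c2nc(O)n(Cc3ccccc3)c2n1` is the next point. Its difference from compound 3 is propyl in place of ethylamino on an aromatic carbon. Going by the values given here, two measured steps bear directly on this kind of exchange at the same aromatic carbon: the loss of the chain-bound nitrogen on going from methylamino to methyl gave no change at the digits printed from compound 1 to compound 2 (within the scatter), and the reverse direction, methyl to ethylamino, gave no change at the digits printed from compound 2 to compound 3 (within the scatter). Both left the minimum effective concentration unchanged within scatter, as did the chain lengthening in no change at the digits printed from compound 1 to compound 3 (within the scatter). On that basis the expectation for compound 4 is no step beyond the scatter, no change at the digits printed from compound 3 to compound 4 (within the scatter). Compound 4 is estimated at 1 uM, with a range of 0.5 uM to 2 uM.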

Compound 4, minimum effective concentration: 1 uM
For compound 4 middle estimate and measured number coincide at the digits printed, and the stated range covers the measured number.
By their numbers in this assay, from the lowest: compounds 1, 2, 3 and 4 (each within the scatter of the next).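

In this assay, propyl in place of ethylamino removes 1 hydrogen-bond donor and 1 hydrogen-bond acceptor while the group stays at 3 heavy atoms, and this gives no change at the digits printed from compound 3 to compound 4 (within the scatter), so the nitrogen can be exchanged for carbon at a matched count of heavy atoms, not only in the shorter methyl of the earlier set. Chain growth on a carbon-linked group is now covered as well: ethyl in place of hydrogen on the saturated chain carbon bound to the aromatic carbon gives no change at the digits printed from compound 2 to compound 4 (within the scatter), whereas the earlier lengthening lay on a nitrogen-linked chain, and propyl in place of methylamino gives no change at the digits printed from compound 1 to compound 4 (within the scatter). No supporting data accompany this flat result to account for it.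

All four groups on this aromatic carbon share one value, so the series does not yet show what would separate them: a longer chain such as hexyl, a phenyl ring, or a carboxylic acid could each still shift the minimum effective concentration. On these data alone, whether the same tolerance holds with another group in place of the benzyl of the shared core also stays open.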